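The compounds below may be only part of what the source reports. "The series", "measured", "known", "first", "only" and "open" are said of these compounds alone.

Compound 2 `Fc1cc2nc(-c3cncnc3C3CC3)n(C3CC3)c2cc1F` stands as the stronger of the two measured compounds: in an assay on cells for inhibition of cytochrome P450 11B2, mitochondrial (Homo sapiens), read by HPLC, with a stated time of 90 min (a higher number here means a weaker inhibitor, a lower number a stronger inhibitor), compound 2 gives 172 nM, whereas compound 1 `Fc1ccc2nc(-c3cn[nH]c3)n(C3CC3)c2c1` gives 782 nM, a gap beyond the usual scatter. Compound 3 `Fc1cc2nc(-c3cncnc3C(F)F)n(C3CC3)c2cc1F` has not been measured yet. It differs from compound 2 in a single place: difluoromethyl in place of cyclopropyl on an aromatic carbon. Among the measured compounds shown here, no measured pair shows what such a swap does, so the expected shift in this assay is small, possibly no larger than the scatter, in either direction. Compound 3 is expected to give about 220 nM in this assay, within a range from 70 nM to 700 nM. This estimate amounts to an expected step of a 1.3-fold higher number from compound 2 to compound 3 (0.11 log units; within the scatter).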

Compound 3, half-maximal inhibitory concentration: 18 nM
The estimate for compound 3 lay 12-fold (1.09 log units) above the measured number, outside the stated range (below it).
By their numbers in this assay, from the lowest: compound 3; then compound 2; then compound 1.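

In this assay, difluoromethyl in place of cyclopropyl on this aromatic carbon brings a 9.6-fold lower number from compound 2 to compound 3 (0.98 log units; beyond the scatter), so the group at this position clearly matters. The two groups have the same count of 3 heavy atoms, so that count alone does not set the number here. Nothing available explains the gain.

Going by these compounds, whether the gain is particular to difluoromethyl stays open, since a methyl or trifluoromethyl group on this carbon would be needed to tell. A single pair also leaves unknown whether the same swap would give a similar step on a different core.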